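From Methyl to Methylcarbamoyl on the Shared Core

A few compounds are considered here, and "the series" means these few. Any claim that something is new, unique, unknown or untested is made for them only; others in the source may bear on it.

Compound 1 `O=C(CCCCCCc1ccccc1)c1nc(C(F)(F)F)co1` is the stronger of the two measured compounds: in an assay on HEK-293T cells for inhibition of diacylglycerol lipase-alpha (Homo sapiens), read by colorimetric assay (a higher number here means a weaker inhibitor, a lower number a stronger inhibitor), compound 1 gives 214 nM. Compound 2 `Cc1coc(C(=O)CCCCCCc2ccccc2)n1` gives only a limit of this assay, > 10000 nM (the limit of > 10000 nM in this assay, at which 1 of the 2 values shown sits). Among the measured compounds shown here, the step of an at least 46-fold higher number from compound 1 to compound 2 (1.66 log units; beyond the scatter) is the one measured change at this ring carbon. Compound 3 `CNC(=O)c1coc(C(=O)CCCCCCc2ccccc2)n1` differs from compound 2 by methylcarbamoyl in place of methyl on an aromatic carbon. For the measured compounds named here, only that single large step bears on it, and the methylcarbamoyl group itself is untested here, so the direction is uncertain. Compound 3 is expected to land between the two measured values, with an estimated 3000 nM (range 500 nM to 10000 nM), a step of an at least 3.3-fold lower number from compound 2 to compound 3 (0.52 log units; beyond the scatter) in this assay.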

Compound 3, half-maximal inhibitory concentration: > 10000 nM
Compound 3: a limit, no number; the forecaster's own chance of this, stated with the estimate: 40%; middle value at least 3.3-fold (0.52 log units) away from the limit.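

Swapping trifluoromethyl for methylcarbamoyl at this ring carbon gives an at least 46-fold higher number from compound 1 to compound 3 (1.66 log units; beyond the scatter), so in this assay a second replacement, one bearing a hydrogen-bond donor and acceptor, also fails to match trifluoromethyl. The step from methyl to methylcarbamoyl cannot be read, and the two compounds can be placed no further than a shared limit: the limit of > 10000 nM in this assay, at which 2 of the 3 values shown sit.

Going by these compounds, it remains open whether a nitrile, a carboxylic acid or a pentafluoroethyl group on this ring carbon would give a measurable value. On these data alone, it also remains open how compound 2 and compound 3 would rank beyond that limit.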